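A fluorophenyl chalcone expected near its methoxy parent

The source may report more compounds than this note shows. Statements on the series, on what has been measured and on what is new or still open speak of the compounds shown alone.

Among the measured compounds shown here, compound 1 `COc1ccccc1/C=C/C(=O)c1ccc(OCC(=O)N[C@H]2CCOC2=O)cc1` is the only compound whose potency in a functional assay on PC-3 cells (Homo sapiens) for antiproliferative activity, read by MTT assay, with a stated time of 72 h (a higher number here means a weaker inhibitor, a lower number a stronger inhibitor), is reported as a number: compound 1 gives 7240 nM. Compound 2 `O=C(CNc1ccc(F)cc1)N[C@H]1CCOC1=O` belongs to a different scaffold, and its result in this assay is a limit of the assay rather than a number, compound 2 giving > 64000 nM. For the measured compounds named here, compound 1 therefore stands alone as the sole numerical value, the other result being (the limit of > 64000 nM in this assay, at which 1 of the 2 values shown sits). Compound 3 `O=C(COc1ccc(C(=O)/C=C/c2cccc(F)c2)cc1)N[C@H]1CCOC1=O` is the chalcone that carries 3-fluorophenyl in place of 2-methoxyphenyl on a double-bonded chain carbon bound to a double-bonded chain carbon. Going by the values given here, no measured pair in this set differs in a single place, so no measured step guides the expectation; exchanging one aromatic substituent for another on the same chain carbon is expected to move the potency by an amount hardly beyond the usual scatter, in no firm direction. The step expected is a 1.2-fold lower number from compound 1 to compound 3 (0.08 log units; within the scatter). Compound 3 is therefore estimated at 6000 nM in this assay, within 2000 nM to 20000 nM.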

Compound 3, half-maximal inhibitory concentration: 23200 nM
For compound 3 the middle estimate is 3.9-fold (0.59 log units) below the measured one, outside the stated range (above it).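

In this assay, among the compounds shown here, this is the first single change that can be read, and exchanging 2-methoxyphenyl for 3-fluorophenyl on a double-bonded chain carbon bound to a double-bonded chain carbon is not neutral (a 3.2-fold higher number from compound 1 to compound 3 (0.51 log units; beyond the scatter)). The position therefore responds to the choice of aromatic group, and of this pair compound 1 is the stronger inhibitor. Nothing measured here bears on why the number rises.

The exchange removes the methoxy group and adds the fluorine in one step, so the compounds shown cannot separate the contribution of each, or that of where each sits on the ring. On these data alone, it also remains open how an unsubstituted phenyl, a hydroxyl or an amine on that ring would read in this assay, and whether any group here would improve on compound 1.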